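The compounds below may be only part of what the source reports. "The series", "measured", "known", "first", "only" and "open" are said of these compounds alone.

Working notes on the series.

For the measured compounds named here, compound 3 `Cc1nc(-c2ccccc2)sc1C(=O)CSc1nc(-c2ccccc2)c(C#N)c(=O)[nH]1` gives 9.23% in a functional assay on U-87MG ATCC cells for antiproliferative activity against U-87 MG (Homo sapiens), read by MTT assay, with a stated time of 48 h, tested at 100 uM (a higher number here means a weaker effect of the compound at the concentration tested, a lower number a stronger effect), the second highest of the three numbers so far. Compound 1 `COc1ccc(-c2nc(C)c(C(=O)CSc3nc(-c4ccc(OC)c(OC)c4)c(C#N)c(=O)[nH]3)s2)cc1` gives 5.39%, within the scatter of compound 3. Going by the values given here, compound 2 `Cc1nc(-c2ccccc2)sc1C(=O)CSc1nc(-c2ccc(Cl)c(Cl)c2)c(C#N)c(=O)[nH]1` gives 24.4%, beyond the scatter above compound 3; the only one-place step in hand is a number 15.2 percentage points lower from compound 2 to compound 3 (beyond the scatter).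

Compound 4 `COc1ccc(-c2nc(SCC(=O)c3sc(-c4ccccc4)nc3C)[nH]c(=O)c2C#N)cc1OC` is not yet measured. It differs from compound 3 by 3,4-dimethoxyphenyl in place of phenyl on an aromatic carbon. Among the compounds with values here, no measured step changes this group from phenyl to 3,4-dimethoxyphenyl, so the step from compound 2 to compound 3 bears on it only by touching the same place, and in the opposite sense. Compound 1 carries the 3,4-dimethoxyphenyl group entering here and sits within the scatter of compound 3, which speaks against a large step. Compound 4 is therefore expected to show a number 2.2 percentage points lower from compound 3 to compound 4 (within the scatter), a change not beyond the scatter, and its estimated value in this assay is 7%, within 2% to 16%.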

Compound 4, a percentage reported as activity, at one concentration (the size of the read-out at that concentration, not a potency): 6.48%
Compound 4: the middle estimate sits 0.5 percentage points above what was measured, within the range that was stated.
By their numbers in this assay, from the lowest: compounds 1, 4 and 3 (each within the scatter of the next); then compound 2.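

At the aromatic carbon ortho to a cyano group, 3,4-dimethoxyphenyl can now be read directly against phenyl in this assay, and the step shows a number 2.8 percentage points lower from compound 3 to compound 4 (within the scatter) with no separation between the two groups. Against 3,4-dichlorophenyl, the same group gives a number 17.9 percentage points lower from compound 2 to compound 4 (beyond the scatter) at this place, so among the three groups shown only 3,4-dichlorophenyl stands apart. The series also gains a reading of hydrogen in place of methoxy on an aromatic carbon outside this position, with a number 1.1 percentage points higher from compound 1 to compound 4 (within the scatter) and no separation between the two compounds. No measurement in hand explains why 3,4-dichlorophenyl stands apart.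

Every group shown at this place is a substituted or plain phenyl, so the effect of an amine such as morpholine or of a carboxylic acid there remains open. Going by these compounds, whether a single chlorine or a single methoxy on the phenyl would follow compound 2 or compound 4 also remains open, and these single-concentration readings give no potency.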